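The source may hold more compounds than are shown below. What is called first, only, known or untested is meant among the compounds shown, and "the series" means these compounds.

Three compounds share one core and differ only in the group on the outer aromatic ring. In a functional assay on HEK293 cells for agonist activity at Bombesin receptor subtype-3 (Mus musculus), read by luminescence and calcium flux, with a stated time of 10 min (a lower number here means that less compound is needed, a higher number that more compound is needed for the effect), compound 1 `CCC(C)(C)Cc1c[nH]c(CCc2ccc(-c3cccc(C#N)n3)cc2)n1` gives 26 nM, compound 2 `CCC(C)(C)Cc1c[nH]c(CCc2ccc(-c3ccc(F)cn3)cc2)n1` gives 16 nM, and compound 3 `CCC(C)(C)Cc1c[nH]c(CCc2ccc(-c3cnsc3)cc2)n1` gives 6.9 nM, the lowest number of the three. The steps of a 3.8-fold lower number from compound 1 to compound 3 (0.58 log units; beyond the scatter) and a 2.3-fold lower number from compound 2 to compound 3 (0.37 log units; beyond the scatter) are modest, while a 1.6-fold lower number from compound 1 to compound 2 (0.21 log units; within the scatter) stays within the scatter. Compound 4 `CCC(C)(C)Cc1c[nH]c(CCc2ccc(N3CCCCC3)cc2)n1` differs from compound 3 in one place: piperidin-1-yl in place of 1,2-thiazol-4-yl on an aromatic carbon. Among the compounds with values here, none of the measured steps swaps an aromatic ring for a non-aromatic one, so the earlier steps only show how far this position has moved the number so far. A modest upward step is expected: a 2.9-fold higher number from compound 3 to compound 4 (0.46 log units; beyond the scatter). For compound 4 in this assay the estimate is 20 nM, within 5 nM to 80 nM.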

Compound 4, half-maximal effective concentration: 28 nM
Estimate against measurement, compound 4: 1.4-fold (0.15 log units) below; the measured number falls inside the stated range.
By their numbers in this assay, from the lowest: compound 3; then compounds 2, 1 and 4 (each within the scatter of the next).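

Piperidin-1-yl puts a non-aromatic ring at this position for the first time, and the number does not separate from those of the two pyridine-bearing compounds: a 1.8-fold higher number from compound 2 to compound 4 (0.24 log units; within the scatter) and a 1.1-fold higher number from compound 1 to compound 4 (0.03 log units; within the scatter) both stay within the scatter. Only 1,2-thiazol-4-yl stands apart, with a 4.1-fold higher number from compound 3 to compound 4 (0.61 log units; beyond the scatter) being a modest step beyond the scatter. Among these compounds, then, an aromatic ring here is not needed to match compound 1 and compound 2, though compound 3 keeps the lowest number.

Going by these compounds, whether morpholin-4-yl, pyrrolidin-1-yl or an open-chain dimethylamino group would behave like piperidin-1-yl remains open. Why 1,2-thiazol-4-yl differs also stays open, as no evidence bears on it.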